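Fluorine on the anilide ring of a pyridazinone amide

The source may report more compounds than this note shows. Statements on the series, on what has been measured and on what is new or still open speak of the compounds shown alone.

Measured compounds:
compound 1, `O=C(Nc1ccc(Oc2ccnc3[nH]ccc23)cc1)c1nn(-c2ccc(Cl)c(F)c2)ccc1=O`, 3110 nM;
compound 2, `O=C(Nc1ccc(Oc2ccnc3[nH]ccc23)cc1)c1nn(-c2ccc(Cl)c(C(F)(F)F)c2)ccc1=O`, 6270 nM;
compound 3, `COc1ccc(-n2ccc(=O)c(C(=O)Nc3ccc(Oc4ccnc5[nH]ccc45)c(F)c3)n2)cc1`, 55400 nM.

In a functional assay on MCF7 cells (Homo sapiens) for cytotoxicity, read by MTT assay, with a stated time of 72 h (on this read-out higher numbers stand for weaker inhibition and lower numbers for stronger inhibition), compound 2 gives the second highest of the three numbers; its nearest neighbour is compound 1, with a 2.0-fold higher number from compound 1 to compound 2 (0.30 log units; within the scatter), and its furthest is compound 3, whose number lies beyond the scatter above it. Compound 4, `O=C(Nc1ccc(Oc2ccnc3[nH]ccc23)c(F)c1)c1nn(-c2ccc(Cl)c(C(F)(F)F)c2)ccc1=O`, differs from compound 2 by fluoro in place of hydrogen on an aromatic carbon, set ortho to a large group and meta to a large group. Among the compounds with values here, no measured step concerns this change alone; compound 3 carries the same fluoro but also a different aryl group, so its value and that of compound 2 merely show a wide gap. The step is therefore expected to be small in this assay, as a 1.2-fold higher number from compound 2 to compound 4 (0.08 log units; within the scatter). Compound 4 is accordingly estimated at 7500 nM, between 2500 nM and 22000 nM.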

Compound 4, half-maximal inhibitory concentration: 11600 nM
The estimate for compound 4 lay 1.5-fold (0.19 log units) below the measured number, and the stated range covers the measured number.
By their numbers in this assay, from the lowest: compounds 1, 2 and 4 (each within the scatter of the next, the first and the last beyond it); then compound 3.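

In this assay, within the data shown here, fluoro in place of hydrogen on this aromatic carbon, ortho to a large group and meta to a large group, gives a 1.9-fold higher number from compound 2 to compound 4 (0.27 log units; within the scatter) and so leaves no step that stands out from the scatter. With the fluoro held constant, 4-chloro-3-(trifluoromethyl)phenyl in place of 4-methoxyphenyl on the aromatic nitrogen gives a 4.8-fold lower number from compound 3 to compound 4 (0.68 log units; beyond the scatter) and so locates a step beyond the scatter at that aryl group. No evidence here accounts for the size of either step. The compounds shown leave open how an amine or a nitrile on this carbon would read, and whether the fluoro step stays the same with other aryl groups on the nitrogen.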